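A few compounds are considered here, and "the series" means these few. Any claim that something is new, unique, unknown or untested is made for them only; others in the source may bear on it.

Measured so far in the series:
compound 1, `O=C(O)[C@@H]1CCCN1C(=O)CN(c1nc(Cl)nc2[nH]cnc12)C1CC1`, giving 31.5%
compound 2, `NCCCC[C@H](NC(=O)CN(c1nc(Cl)nc2[nH]cnc12)C1CC1)C(=O)O`, giving 31.2%
compound 3, `CC(C)[C@H](NC(=O)CN(c1nc(Cl)nc2[nH]cnc12)C1CC1)C(=O)O`, giving 31.2%

Compound 3 in a functional assay on the whole organism (Tail, strain ICR) with Mus musculus as the target, in the tail flick test, with a stated time of 30 min, at a dose of 25 umol/kg by the oral route (a lower number here means a weaker effect, a higher number a stronger effect of the compound at the dose given), stands level with compound 2 at the digits printed; the two are together the lowest of the three numbers. The nearest measured neighbour is compound 2, with no change at the digits printed from compound 2 to compound 3 (within the scatter). The furthest is compound 1, with a number 0.3 percentage points lower from compound 1 to compound 3 (within the scatter). Both steps lie within the usual scatter, so the three measured compounds show no spread that can be read as a difference.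

Compound 4, `C[C@H](NC(=O)CN(c1nc(Cl)nc2[nH]cnc12)C1CC1)C(=O)O`, is the next member. It differs from compound 3 as follows: methyl in place of isopropyl on a saturated chain carbon bound to an amide-type nitrogen and a carbonyl carbon. The step that bears most directly on this change is the one on the same carbon, from compound 2 to compound 3, where 4-aminobutyl was exchanged for isopropyl with no change at the digits printed from compound 2 to compound 3 (within the scatter). The more distant exchange of the whole 2-carboxypyrrolidin-1-yl group for (1-carboxy-2-methylpropyl)amino gave a number 0.3 percentage points lower from compound 1 to compound 3 (within the scatter). Neither exchange at this position moved the read-out beyond the scatter. A smaller group entering at the same place is therefore expected to leave the number where it is, with an expected step of a number 0.2 percentage points lower from compound 3 to compound 4 (within the scatter) in this assay .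

For compound 4 the estimate in this assay is 31%, with a range from 21% to 41%.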

Compound 4, a percentage reported as activity, at one dose (the size of the read-out at that dose, not a potency): 48.1%
Estimate against measurement, compound 4: 17.1 percentage points below; measured number outside the range, above it.
By their numbers in this assay, from the lowest: compounds 2, 3 and 1 (each within the scatter of the next); then compound 4.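

In this assay, the saturated chain carbon bound to an amide-type nitrogen and a carbonyl carbon proves sensitive to the group it carries: methyl in place of isopropyl gives a number 16.9 percentage points higher from compound 3 to compound 4 (beyond the scatter), whereas the earlier exchange at this carbon stayed within the scatter. The other two routes agree, with a number 16.9 percentage points higher from compound 2 to compound 4 (beyond the scatter) for hydrogen in place of 3-aminopropyl on a saturated chain carbon, two bonds along the chain from an amide-type nitrogen and a carbonyl carbon, and a number 16.6 percentage points higher from compound 1 to compound 4 (beyond the scatter) for (1-carboxyethyl)amino in place of 2-carboxypyrrolidin-1-yl on a carbonyl carbon. The read-out therefore does not follow a graded trend with the size of the group, since isopropyl and 4-aminobutyl stand level and only methyl separates from them.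

Nothing available explains why the methyl compound separates from the others. Going by these compounds, it remains open whether the rise is specific to methyl or extends to an ethyl group or a bare hydrogen on the same carbon, and whether it survives replacing the carboxylic acid of compound 4 with a methyl ester or a primary amide.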